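A few compounds are considered here, and "the series" means these few. Any claim that something is new, unique, unknown or untested is made for them only; others in the source may bear on it.

Compound 2 `Oc1ccccc1-c1cc(-c2ccc(OC(F)(F)F)cc2)cc(-c2ccccc2O)n1` carries two 2-hydroxyphenyl groups on its shared core. In a functional assay on T47D cells (Homo sapiens) for inhibition (a lower number here means a stronger inhibitor, a higher number a weaker inhibitor), compound 2 gives only a limit of the assay, > 50000 nM, and no number. Compound 1 `Oc1cccc(-c2cc(-c3ccc(F)cc3)cc(-c3ccccc3O)n2)c1`, a close relative, in this assay likewise reaches only a limit, > 50000 nM. Both values sit at the same limit (the limit of > 50000 nM in this assay, at which 2 of the 2 values shown sit), so compound 2 stands no better than anything measured. Compound 3 `Oc1cccc(-c2cc(-c3ccc(OC(F)(F)F)cc3)cc(-c3ccccc3O)n2)c1` differs from compound 2 by 3-hydroxyphenyl in place of 2-hydroxyphenyl on an aromatic carbon. The expected step that the limit leaves unreadable from compound 2 to compound 3 is none beyond the scatter. Compound 3 is therefore expected to give about 70000 nM in this assay, within 30000 nM to 200000 nM, most likely again only a limit.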

Compound 3, half-maximal inhibitory concentration: 7710 nM
The estimate for compound 3 lay 9.1-fold (0.96 log units) above the measured number; measured number below the stated range.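

On the carbon next to the ring nitrogen, the place of the hydroxyl on the phenyl group matters in this assay: 3-hydroxyphenyl in place of 2-hydroxyphenyl gives an at least 6.4-fold lower number from compound 2 to compound 3 (0.81 log units; beyond the scatter). Trifluoromethoxy in place of fluoro also matters, giving an at least 6.4-fold lower number from compound 1 to compound 3 (0.81 log units; beyond the scatter). Of the compounds shown, only compound 3 carries both 3-hydroxyphenyl and trifluoromethoxy, and only compound 3 gives a number rather than a limit.

From the compounds shown here alone, the true size of each step stays open, since each starts from a limit: the limit of > 50000 nM in this assay, at which 2 of the 3 values shown sit. Also open is what an amine or a carboxylic acid would do in place of that hydroxyl.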